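Ethoxy-type and propyl-type side chains at the assay limit

A few compounds are considered here, and "the series" means these few. Any claim that something is new, unique, unknown or untested is made for them only; others in the source may bear on it.

Values in a toxicity assay on MT2 cells (Homo sapiens) for cytotoxicity, read by XTT assay, with a stated time of 4 days (a higher number here means that more compound is tolerated, a lower number that less compound is tolerated), all of them limits:
- compound 1 `COc1cccc(CCOc2ccc(-c3c(C)nc(C)c([C@H](OC(C)(C)C)C(=O)O)c3N3CCC(C)(C)CC3)cc2)c1`: >= 33500 nM
- compound 2 `Cc1nc(C)c([C@H](OC(C)(C)C)C(=O)O)c(N2CCC(C)(C)CC2)c1-c1ccc(OCCc2ccc(F)cc2F)cc1`: >= 33500 nM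
- compound 3 `Cc1nc(C)c([C@H](OC(C)(C)C)C(=O)O)c(N2CCC(C)(C)CC2)c1-c1ccc(CCCc2ccc(F)cc2)cc1`: >= 32000 nM

Compound 3 stands at the limit of >= 32000 nM in this assay, at which 1 of the 3 values shown sits, which is a limit and not a number. Compound 4 `Cc1nc(C)c([C@H](OC(C)(C)C)C(=O)O)c(N2CCC(C)(C)CC2)c1-c1ccc(OCCCc2ccc(F)cc2)cc1` carries 3-(4-fluorophenyl)propoxy in place of 3-(4-fluorophenyl)propyl on an aromatic carbon. The closest comparisons are a step that the two limits leave unreadable from compound 1 to compound 3 and a step that the two limits leave unreadable from compound 2 to compound 3, and neither gives a size. Compound 1 and compound 2, which carry 2-(3-methoxyphenyl)ethoxy and 2-(2,4-difluorophenyl)ethoxy, sit at the limit of >= 33500 nM in this assay, at which 2 of the 3 values shown sit. In this assay no step beyond the scatter is expected, and the expected step is a step that the limit leaves unreadable from compound 3 to compound 4. Another limit is the likely report. Compound 4 is estimated at 33000 nM, with an expected range of 17000 nM to 65000 nM.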

Compound 4, half-maximal cytotoxic concentration: >= 32000 nM
Compound 4: only a limit was reported (the forecaster's own chance of this, stated with the estimate: 85%); the middle value is on the limit's open side.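

In this assay compound 4 gives >= 32000 nM as a limit. For the compounds shown here, no step from compound 1, compound 2 or compound 3 to compound 4 can be read. The compounds shown leave open where the actual half-maximal cytotoxic concentration of each of these four compounds lies.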